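Swapping in 4-Cyanophenyl Where Every Value Is a Limit

The source may hold more compounds than are shown below. What is called first, only, known or untested is meant among the compounds shown, and "the series" means these compounds.

Three related compounds have been tested in a functional assay on ECV-304 cells (Homo sapiens) for cytotoxicity; a higher number here means a weaker inhibitor, a lower number a stronger inhibitor: compound 1 (`COc1ccc(S(=O)(=O)NN2C(=S)S/C(=C\c3ccc(Cl)c(Cl)c3)C2O)cc1`), compound 2 (`Cc1cccc(/C=C2\SC(=S)N(NS(=O)(=O)c3ccccc3)C2=O)c1`) and compound 3 (`O=C1/C(=C/c2ccccc2F)SC(=S)N1NS(=O)(=O)c1ccccc1`). Compound 1 gives > 50000 nM, which is a limit and not a number. Compound 2 gives > 50000 nM, also a limit. Compound 3 gives > 50000 nM, again a limit, so it offers no exact starting number. The overall picture is the limit of > 50000 nM in this assay, at which 3 of the 3 values shown sit.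

Compound 4 (`N#Cc1ccc(/C=C2\SC(=S)N(NS(=O)(=O)c3ccccc3)C2=O)cc1`) differs from compound 3 in one group: 4-cyanophenyl in place of 2-fluorophenyl on a double-bonded chain carbon bound to a double-bonded ring carbon. Among the compounds with values here, the one measured step at this place is a step that the two limits leave unreadable from compound 2 to compound 3, so it offers no size to carry over. With no measured size to draw on, no clear change is expected, in either direction, and another limit is the likeliest result. The expected change is a number no higher from compound 3 to compound 4 (the limit leaves the size open). For compound 4 the estimated value is 50000 nM, with an expected range of 20000 nM to 100000 nM.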

Compound 4, half-maximal inhibitory concentration: > 50000 nM
Compound 4 was reported as a limit; the forecaster's own chance of this, stated with the estimate: 80%; the middle value lies on the limit itself.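

In this assay compound 4 gives > 50000 nM, again a limit and not a number, so the steps to it from compound 2 and compound 3 cannot be read. The compounds shown leave open how strong any of them actually is, and whether any group at this place matters: the limit of > 50000 nM in this assay, at which 4 of the 4 values shown sit.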